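Swapping nitro for methyl on a cyanoguanidine aryl ring

The source may report more compounds than this note shows. Statements on the series, on what has been measured and on what is new or still open speak of the compounds shown alone.

Measured compounds:
- compound 1, `CC1(C)Oc2ccc(C#N)cc2[C@@H](N2CCN(c3ccccc3)C2=O)[C@@H]1O`: 23700 nM
- compound 2, `CC1(C)Oc2ccc(C#N)cc2[C@@H](/N=C(\NC#N)Nc2cccc([N+](=O)[O-])c2)[C@@H]1O`: 670 nM

Of the compounds shown here, two share a core and have been tested in a functional assay (aorta) with Rattus norvegicus as the target; a lower number here means a stronger inhibitor, a higher number a weaker inhibitor. Compound 1 carries a cyclic urea and gives 23700 nM. Compound 2 carries a cyanoguanidine with a (3-nitrophenyl)amino group and gives 670 nM, the lowest of the two numbers; the gap from compound 1 lies well beyond the usual scatter, so compound 2 is the stronger inhibitor of this pair.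

Compound 3, `Cc1cccc(N/C(=N/[C@@H]2c3cc(C#N)ccc3OC(C)(C)[C@H]2O)NC#N)c1`, has not yet been measured in this assay. It differs from compound 2 as follows: methyl in place of nitro on an aromatic carbon. Among the measured compounds shown here, no measured pair shows this change, so its effect is open. Compound 3 is expected to remain a stronger inhibitor than compound 1 but somewhat weaker than compound 2. The expected step is estimated as a 2.7-fold higher number from compound 2 to compound 3 (0.43 log units; beyond the scatter). Compound 3 is estimated to give 1800 nM in this assay, within an expected range of 450 nM to 7000 nM.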

Compound 3, half-maximal inhibitory concentration: 1000 nM
Beside the measured number, compound 3's estimate is 1.8-fold (0.26 log units) above it, and the stated range covers the measured number.
By their numbers in this assay, from the lowest: compounds 2 and 3 (each within the scatter of the next); then compound 1.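

In this assay, the change from 3-nitrophenyl to 3-methylphenyl gives a 1.5-fold higher number from compound 2 to compound 3 (0.17 log units; within the scatter), so the two compounds cannot be told apart at this position. The exchange is not a small one on paper: the nitro group has 3 heavy atoms and 2 hydrogen-bond acceptors, whereas the methyl group has 1 heavy atom and no hydrogen-bond acceptors, yet the read-out barely registers it. Nothing available here gives a reason why these two groups read alike.

The compounds shown leave open whether this tolerance extends to other groups on the same aromatic carbon, such as an amine, a carboxylic acid or a longer chain like propyl. They also leave open what a plain phenyl ring with only hydrogen at that carbon would give.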